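Compound 3 to compound 4: a larger aryl group on nitrogen

This account rests on a few compounds, and the source may have more. Where it says the series, first, only, none or still open, it means among the compounds named here.

Values in a functional assay on HeLa cells (Homo sapiens) for cytotoxicity, read by MTT assay, with a stated time of 72 h; on this read-out higher numbers stand for weaker inhibition and lower numbers for stronger inhibition:
- compound 1 `Cn1ccc2c(Oc3ccc(NC(=O)c4cc5cccnc5n(-c5ccc(Cl)cc5)c4=O)cc3)ncnc21`: 49900 nM
- compound 2 `COc1ccc(-n2c(=O)c(C(=O)Nc3ccc(Oc4ncnc5c4ccn5C)cc3)cc3cccnc32)cc1`: 65800 nM
- compound 3 `Cn1ccc2c(Oc3ccc(NC(=O)c4cc5cccnc5n(-c5ccccc5)c4=O)cc3F)ncnc21`: 51800 nM

In this assay compound 3 gives 51800 nM, within the scatter of both other compounds, so the three values do not separate. The next compound is compound 4 `Cn1ccc2c(Oc3ccc(NC(=O)c4cc5cccnc5n(-c5ccc(C(F)(F)F)c(Cl)c5)c4=O)cc3F)ncnc21`, with 3-chloro-4-(trifluoromethyl)phenyl in place of phenyl on an aromatic nitrogen.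

Among the compounds with values here, only one measured step bears on this change. It is a 1.3-fold higher number from compound 1 to compound 2 (0.12 log units; within the scatter), a swap on the aryl group at the same nitrogen, and it stays within the scatter. Within the data shown here, that step is a thin basis, since no measured compound carries two substituents on this ring and none carries trifluoromethyl. No step beyond the scatter is therefore expected in this assay, and any direction is tentative, with a small move to a lower number only slightly favoured. The expected step is a 1.3-fold lower number from compound 3 to compound 4 (0.11 log units; within the scatter). For compound 4 the estimated value is 40000 nM, with an expected range of 16000 nM to 85000 nM.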

Compound 4, half-maximal inhibitory concentration: 156000 nM
For compound 4 the middle estimate is 3.9-fold (0.59 log units) below the measured one, outside the stated range (above it).
By their numbers in this assay, from the lowest: compounds 1, 3 and 2 (each within the scatter of the next); then compound 4.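

In this assay, the aryl group on this aromatic nitrogen now produces a step beyond the scatter: a 3.0-fold higher number from compound 3 to compound 4 (0.48 log units; beyond the scatter), the direction of weaker inhibition, with 3-chloro-4-(trifluoromethyl)phenyl in place of phenyl. The earlier change on this aryl group, methoxy in place of chloro, gave only a 1.3-fold higher number from compound 1 to compound 2 (0.12 log units; within the scatter), so the series had not previously shown that this position could move the read-out beyond the scatter. No measurement available here accounts for the weaker inhibition.

The compounds shown do not separate the contribution of the chloro from that of the trifluoromethyl within the new group. Also open, as far as these compounds go, is how an aryl group carrying an amine or a carboxylic acid, or an alkyl chain in place of the aryl group on this nitrogen, would read in this assay.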